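A few compounds are considered here, and "the series" means these few. Any claim that something is new, unique, unknown or untested is made for them only; others in the source may bear on it.

Compound 1 `Cc1ccccc1S(=O)(=O)c1ccc(CNC(=O)c2cc3cnccc3[nH]2)cc1`: 15%
Compound 2 `O=C(NCc1ccc(S(=O)(=O)c2ccccc2)cc1)c1nc2ccncc2s1`: 26%

In an ADME assay on microsomes from liver (Mus musculus) for metabolic stability, read by LC-MS, with a stated time of 30 min, tested at 1 uM (on this read-out lower numbers stand for a less stable compound and higher numbers for a more stable compound), compound 1 gives 15%, the lower of the two numbers, while compound 2 reaches 26%, a gap beyond the usual scatter. Compound 3 `O=C(NCc1ccc(S(=O)(=O)c2cccc(F)c2)cc1)c1cc2cnccc2[nH]1` has not yet been measured. It differs from compound 1 by one change: 3-fluorophenyl in place of 2-methylphenyl on a sulfonyl sulfur, with 3-fluorophenyl in place of 2-methylphenyl on a sulfonyl sulfur. Going by the values given here, no measured pair shows this change alone, so the forecast is loose. In this assay, a small rise is expected, possibly none beyond the scatter: a number 9 percentage points higher from compound 1 to compound 3 (within the scatter). For compound 3, the estimated value is 24%, with an expected range from 10% to 45%.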

Compound 3, percent of the compound remaining: 44%
The estimate for compound 3 lay 20 percentage points below the measured number; low and high end bracket the measured number.
By their numbers in this assay, from the lowest: compound 1; then compound 2; then compound 3.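

In this assay, the group on the sulfonyl sulfur clearly matters: 3-fluorophenyl in place of 2-methylphenyl gives a number 29 percentage points higher from compound 1 to compound 3 (beyond the scatter). The two groups have the same count of heavy atoms and the same counts of hydrogen-bond donors and acceptors, yet the read-out still moves. No available measurement bears on why it rose. The compounds shown leave open whether losing the methyl or gaining the fluorine accounts for the step. They also leave open how a methoxy group or an amine on that ring would behave, and whether the same swap holds on the core of compound 2.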